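The source may hold more compounds than are shown below. What is called first, only, known or untested is meant among the compounds shown, and "the series" means these compounds.

Going by the values given here, in a functional assay on CCRF-CEM cells (Homo sapiens) for cytotoxicity, read by propidium iodide staining, with a stated time of 48 h (a higher number here means that more compound is tolerated, a lower number that less compound is tolerated), two compounds sharing one core have numbers so far. Compound 1 `O=C(CN1C(=O)S/C(=C/c2ccco2)C1=O)Nc1ccc(Cl)c(Cl)c1` gives 7800 nM, while compound 2 `O=C(CN1C(=O)S/C(=C/c2ccco2)C1=O)Nc1ccc(Br)cc1` gives 81000 nM, the higher of the two. Among the compounds with values here, the one measured step, a 10-fold higher number from compound 1 to compound 2 (1.02 log units; beyond the scatter), is large and exchanges the halogenated aryl group on the amide-type nitrogen.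

Compound 3 `Cc1ccc(NC(=O)CN2C(=O)S/C(=C/c3ccco3)C2=O)cc1` differs from compound 2 at a single place: methyl in place of bromo on an aromatic carbon, with methyl in place of bromo on an aromatic carbon, para to a large group. The measured step bears on this change only loosely. Within the data shown here, it alters the same aryl group, but it removes chlorine and brings in bromine, and no measured pair exchanges bromo for methyl. Its size therefore cannot simply be carried over, and it gives no firm direction. The expectation rests mainly on compound 2 at 81000 nM, with no step beyond the scatter foreseen and only a slight drift to a lower number. The expected change is a 1.2-fold lower number from compound 2 to compound 3 (0.06 log units; within the scatter). Compound 3 is estimated at 70000 nM, with an expected range from 25000 nM to 200000 nM.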

Compound 3, half-maximal cytotoxic concentration: 102000 nM
Estimate against measurement, compound 3: 1.5-fold (0.16 log units) below; low and high end bracket the measured number.
By their numbers in this assay, from the lowest: compound 1; then compounds 2 and 3 (each within the scatter of the next).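

At the place para to a large group, the exchange of bromo for methyl in this assay gives a 1.3-fold higher number from compound 2 to compound 3 (0.10 log units; within the scatter), so this change separates compound 2 and compound 3 by no more than the usual scatter of the read-out, even though a halogen gives way to a carbon group of the same heavy-atom count. The large step seen earlier is thus not tied to the 4-bromophenyl group alone: replacing the 3,4-dichlorophenyl group of compound 1 with 4-methylphenyl gives a 13-fold higher number from compound 1 to compound 3 (1.12 log units; beyond the scatter), which sits alongside a 10-fold higher number from compound 1 to compound 2 (1.02 log units; beyond the scatter), and among these three compounds only compound 1, the one with two chlorines on the aryl ring, tolerates a clearly lower concentration. The data offer no measured evidence that explains either the large steps or the lack of a step between bromo and methyl.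

The three compounds leave open whether the lower number of compound 1 depends on one chlorine, on the other, or on the pair together. They also leave open whether an amine or a carboxylic acid para to a large group would stay with compound 2 and compound 3 or move the number beyond the scatter.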